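A few compounds are considered here, and "the series" means these few. Any claim that something is new, unique, unknown or untested is made for them only; others in the source may bear on it.

Measured compounds:
- compound 1, `C#CCOc1ccc(/C=C/C(=O)c2ccc(Br)cc2)cc1`: 34%
- compound 2, `C#CCOc1ccc(/C=C/C(=O)c2ccc(OC)cc2)cc1`: 32%
- compound 3, `O=C(/C=C/c1ccc(OCc2cn(Cc3ccccc3Br)nn2)cc1)c1ccc(Br)cc1`: 43%

In a functional assay on MIA PaCa-2 cells (Homo sapiens) for inhibition, read by MTT assay, with a stated time of 48 h, tested at 10 uM (a lower number here means less inhibition of growth, a higher number more inhibition of growth at the concentration tested), compound 3 gives the highest of the three numbers. Its value and that of compound 1 are within the scatter of each other, so no order between them can be claimed; only compound 2 lies beyond the scatter below compound 3. Within the data shown here, the one measured step, a number 2 percentage points lower from compound 1 to compound 2 (within the scatter), concerns the aryl ketone end of the shared core and stayed within the scatter.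

Compound 4, `O=C(/C=C/c1ccc(OCc2cn(Cc3cccc(F)c3)nn2)cc1)c1ccc(Br)cc1`, differs from compound 3 at the other end of the molecule: 3-fluorophenyl in place of 2-bromophenyl on a saturated chain carbon bound to an aromatic nitrogen. Among the measured compounds shown here, no measured step touches this part of the structure, so the expectation rests only on the general picture, in which the single change that was measured, that from compound 1 to compound 2, left this assay essentially unchanged. Compound 4 is therefore expected to show no step beyond the scatter, a number 3 percentage points lower from compound 3 to compound 4 (within the scatter), and is estimated at 40%, within a range from 25% to 55%.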

Compound 4, percent growth inhibition at one concentration: 34%
Compound 4: middle estimate off by 6 percentage points, on the high side; the range from low to high includes it.
By their numbers in this assay, from the lowest: compounds 2, 1, 4 and 3 (each within the scatter of the next, the first and the last beyond it).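

In this assay, among these compounds, the change from 2-bromophenyl to 3-fluorophenyl gives a number 9 percentage points lower from compound 3 to compound 4 (within the scatter) and is the first measured step at this end of the molecule, so this position has now taken one change without a step beyond the scatter. That step alters both the halogen and its place on the phenyl ring, and these two changes cannot be read apart from compounds 3 and 4 alone. No available evidence bears on the reason for this result.

The compounds shown leave open how an unsubstituted phenyl, or a phenyl carrying only one of these two halogens at the other ring position, would compare. They also leave open whether an amine, a carboxylic acid or a longer chain in place of the benzyl group would move the number beyond the scatter.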